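The source may hold more compounds than are shown below. What is called first, only, known or untested is meant among the compounds shown, and "the series" means these compounds.

Measured in a physicochemical assay for solubility, measured as kinetic solubility; a lower number here means a less soluble compound, a higher number a more soluble compound:
compound 1 `C[C@H](NC(=O)c1cc(C(F)(F)F)nn1C)c1nc(-c2ccnc(N3CCCC3)c2)no1` gives 41000 nM
compound 2 `COCc1cc(-c2noc([C@H](C)NC(=O)c3cc(C(F)(F)F)nn3C)n2)ccn1` gives 200000 nM
compound 3 `C[C@H](NC(=O)c1cc(C(F)(F)F)nn1C)c1nc(-c2ccnc(C(F)F)c2)no1` gives 178000 nM

Compound 1 stands lowest of the three. Compound 4 `C[C@H](NC(=O)c1cc(C(F)(F)F)nn1C)c1nc(-c2ccnc(C(F)(F)F)c2)no1` is not yet measured in this assay and carries trifluoromethyl in place of pyrrolidin-1-yl on an aromatic carbon, next to the ring nitrogen: trifluoromethyl in place of pyrrolidin-1-yl on an aromatic carbon. Two measured steps replace the same pyrrolidin-1-yl: a 4.9-fold higher number from compound 1 to compound 2 (0.69 log units; beyond the scatter), and a 4.3-fold higher number from compound 1 to compound 3 (0.64 log units; beyond the scatter). The two replacements themselves lie close: a 1.1-fold lower number from compound 2 to compound 3 (0.05 log units; within the scatter). A modest step of similar size toward a higher number is therefore expected: a 3.7-fold higher number from compound 1 to compound 4 (0.56 log units; beyond the scatter). For compound 4 the estimated value is 150000 nM, with an expected range of 70000 nM to 260000 nM.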

Compound 4, solubility: 58000 nM
Beside the measured number, compound 4's estimate is 2.6-fold (0.41 log units) above it, and the stated range ends above it.
By their numbers in this assay, from the lowest: compounds 1 and 4 (each within the scatter of the next); then compounds 3 and 2 (each within the scatter of the next).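

Removing pyrrolidin-1-yl does not by itself raise the number in this assay: with trifluoromethyl in its place, the step stays within the scatter (a 1.4-fold higher number from compound 1 to compound 4 (0.15 log units; within the scatter)). At this position, a single added fluorine on the chain carbon separates compound 4 from compound 3 (a 3.1-fold lower number from compound 3 to compound 4 (0.49 log units; beyond the scatter)), and compound 4 also stands apart from compound 2 (a 3.4-fold lower number from compound 2 to compound 4 (0.54 log units; beyond the scatter)). No evidence bearing on these steps is available.

As far as these compounds go, whether monofluoromethyl or a nitrile would fall with compound 3 or with compound 4 stays open. So does whether a smaller amine such as dimethylamino would track compound 1.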